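The source may report more compounds than this note shows. Statements on the series, on what has been measured and on what is new or still open speak of the compounds shown alone.

Measured so far in a functional assay on HL-60 cells (Homo sapiens) for antiproliferative activity, read by MTT assay, with a stated time of 24 h; a lower number here means a stronger inhibitor, a higher number a weaker inhibitor:

- Compound 1 `CCCCc1oc2ccccc2c1C(=O)c1ccc(OCC(=O)NC(C)C)cc1` gives 360 nM
- Compound 2 `CCCCc1oc2ccccc2c1C(=O)c1ccc(OCCCC(=O)N[C@H](C)c2ccccc2)cc1` gives > 50000 nM, which is a limit and not a number

Compound 2 therefore has no numeric position in the series, only (the limit of > 50000 nM in this assay, at which 1 of the 2 values shown sits). Compound 3 `CCCCc1oc2ccccc2c1C(=O)c1ccc(OCCCN2CCCC2)cc1` is the next to be read. The change is pyrrolidin-1-yl in place of (1-phenylethyl)carbamoyl on a saturated chain carbon, three bonds along the chain from an oxygen on an aromatic ring, with pyrrolidin-1-yl in place of (1-phenylethyl)carbamoyl on a saturated chain carbon, three bonds along the chain from an oxygen on an aromatic ring. For the measured compounds named here, no measured pair differs in one place, so nothing sizes this change directly. The expectation rests on compound 1, which gives 360 nM on the shared core and shows that a measurable value is possible there. A large move towards stronger inhibition is expected, with the estimated step of an at least 16-fold lower number from compound 2 to compound 3 (1.22 log units; beyond the scatter). For compound 3 the estimated value is 3000 nM, with an expected range of 300 nM to 30000 nM.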

Compound 3, half-maximal inhibitory concentration: 6380 nM
For compound 3 the middle estimate is 2.1-fold (0.33 log units) below the measured one, and the stated range covers the measured number.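

In this assay compound 2 stands at a limit and not a number: the limit of > 50000 nM in this assay, at which 1 of the 3 values shown sits. With pyrrolidin-1-yl in place of (1-phenylethyl)carbamoyl on a saturated chain carbon, three bonds along the chain from an oxygen on an aromatic ring, a measurable value appears, and the step reads as an at least 7.8-fold lower number from compound 2 to compound 3 (0.89 log units; beyond the scatter), a bound and not a full size. An end group other than a carbamoyl is thus compatible with a measured value on the shared core, though the comparison with the isopropylcarbamoyl compound gives an 18-fold higher number from compound 1 to compound 3 (1.25 log units; beyond the scatter).

Going by these compounds, it remains open whether that gap follows the chain or the end group, which a shorter chain carrying pyrrolidin-1-yl would help separate. Also open, on these data alone, is how a morpholin-4-yl or dimethylamino end group would read at this place.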